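Lengthening the Side Chain to Octyl on the Shared Core

The source may report more compounds than this note shows. Statements on the series, on what has been measured and on what is new or still open speak of the compounds shown alone.

Three measured compounds share one core and differ only in the chain attached to it. Their results in an assay on isolated protein for inhibition of dual specificity calcium/calmodulin-dependent 3',5'-cyclic nucleotide phosphodiesterase 1A (Bos taurus) (a higher number here means a weaker inhibitor, a lower number a stronger inhibitor), are:

Compound 1 `CCCc1nc2c([nH]1)N1C(=N[C@@H]3CCC[C@@H]31)N(C)C2=O`: 350 nM
Compound 2 `CCC(CC)c1nc2c([nH]1)N1C(=N[C@@H]3CCC[C@@H]31)N(C)C2=O`: 150 nM
Compound 3 `CCCCCCCc1nc2c([nH]1)N1C(=N[C@@H]3CCC[C@@H]31)N(C)C2=O`: 160 nM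

Compound 2 has the lowest number of the three in this assay. Its nearest neighbour is compound 3, and the two are within the scatter of each other, so neither can be called the stronger inhibitor. Compound 1 stands furthest away; the step of a 2.3-fold lower number from compound 1 to compound 2 (0.37 log units; beyond the scatter) and the step of a 2.2-fold lower number from compound 1 to compound 3 (0.34 log units; beyond the scatter) both lie beyond the scatter, so a larger chain than propyl has so far gone with a lower number.

The new compound 4 `CCCCCCCCc1nc2c([nH]1)N1C(=N[C@@H]3CCC[C@@H]31)N(C)C2=O` carries octyl in place of pentan-3-yl on an aromatic carbon. The step that bears most directly on this is a 1.1-fold higher number from compound 2 to compound 3 (0.03 log units; within the scatter), which lies within the scatter: swapping the branched pentan-3-yl for a straight heptyl chain made no detectable difference. Octyl is a straight chain one carbon longer than heptyl, so no change beyond the scatter is expected from compound 2 to compound 4, and the expected step is a 1.1-fold higher number from compound 2 to compound 4 (0.03 log units; within the scatter).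

Compound 4 is therefore estimated at 160 nM in this assay, with a range from 80 nM to 320 nM.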

Compound 4, half-maximal inhibitory concentration: 33 nM
Beside the measured number, compound 4's estimate is 4.8-fold (0.69 log units) above it; the whole stated range lies above it.
By their numbers in this assay, from the lowest: compound 4; then compounds 2 and 3 (each within the scatter of the next); then compound 1.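

In this assay, within the data shown here, this position, on an aromatic carbon between two ring nitrogen atoms, proves more responsive to chain length than the earlier compounds suggested: adding one methyl to the end of the heptyl chain gives a 4.8-fold lower number from compound 3 to compound 4 (0.69 log units; beyond the scatter). Octyl also separates clearly from the branched pentan-3-yl, with a 4.5-fold lower number from compound 2 to compound 4 (0.66 log units; beyond the scatter), even though heptyl and pentan-3-yl could not be told apart, so the number does not simply follow the size of the group. Among the three straight chains, the number falls as the chain lengthens, and the full change from propyl to octyl is an 11-fold lower number from compound 1 to compound 4 (1.03 log units; beyond the scatter), the largest step in this set, with compound 4 now clearly the strongest inhibitor of the four.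

Nothing available here explains why this one extra carbon makes such a difference. On these data alone, it also remains open whether a longer chain such as decyl would lower the number further, whether a branched chain as long as octyl would match it, and whether an amine or a carboxylic acid at the end of the chain would be tolerated.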